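Leaving the 4-cyanophenyl group of compound 3

A few compounds are considered here, and "the series" means these few. Any claim that something is new, unique, unknown or untested is made for them only; others in the source may bear on it.

- compound 1 `Cc1ccccc1-c1nc2c(c(C)nn2-c2ccccc2)c(-c2ccccc2O)c1C#N`: 21000 nM
- compound 2 `Cc1nn(-c2ccccc2)c2nc(-c3ccc(C(C)C)cc3)c(C#N)c(-c3ccccc3O)c12`: 9800 nM
- compound 3 `Cc1nn(-c2ccccc2)c2nc(-c3ccc(C#N)cc3)c(C#N)c(-c3ccccc3O)c12`: 1700 nM

In a physicochemical assay for solubility, read by spectrophotometry, in phosphate buffer, with a stated time of 18 h, at pH 7.4 (a lower number here means a less soluble compound, a higher number a more soluble compound), compound 3 gives the lowest of the three numbers, 1700 nM. Compound 4 `Cc1nn(-c2ccccc2)c2nc(-c3ccc4c(c3)OCCO4)c(C#N)c(-c3ccccc3O)c12` differs from it in one place, with 2,3-dihydro-1,4-benzodioxin-6-yl in place of 4-cyanophenyl on an aromatic carbon. Three measured steps change the group at this same place. The two that arrive at the 4-cyanophenyl group are a 5.8-fold lower number from compound 2 to compound 3 (0.76 log units; beyond the scatter) and a 12-fold lower number from compound 1 to compound 3 (1.09 log units; beyond the scatter). The third, which involves neither that group nor compound 3, is smaller: a 2.1-fold lower number from compound 1 to compound 2 (0.33 log units; beyond the scatter). For the measured compounds named here, no measured compound carries the entering group, so the evidence is indirect. Both measured compounds without 4-cyanophenyl lie higher, compound 2 at 9800 nM and compound 1 at 21000 nM. A modest rise is therefore expected, an estimated 3.2-fold higher number from compound 3 to compound 4 (0.51 log units; beyond the scatter). The value expected for compound 4 is 5500 nM, within an estimated range of 1700 nM to 18000 nM.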

Compound 4, solubility: 11000 nM
For compound 4 the middle estimate is 2.0-fold (0.30 log units) below the measured one; low and high end bracket the measured number.
By their numbers in this assay, from the lowest: compound 3; then compounds 2, 4 and 1 (each within the scatter of the next, the first and the last beyond it).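

In this assay the move away from 4-cyanophenyl gives a 6.5-fold higher number from compound 3 to compound 4 (0.81 log units; beyond the scatter) and leaves compound 3 as the only one of the four beyond the scatter of all the others, now against three different groups at this aromatic carbon. The 2,3-dihydro-1,4-benzodioxin-6-yl group cannot be separated from the two other groups, since a 1.1-fold higher number from compound 2 to compound 4 (0.05 log units; within the scatter) and a 1.9-fold lower number from compound 1 to compound 4 (0.28 log units; within the scatter) both sit within the scatter, even though compound 1 and compound 2 lie beyond it from each other. Nothing among the data accounts for these differences.

On these data alone, what a 3,4-dimethoxyphenyl group, or a phenyl carrying an amine or a carboxylic acid, would give at this place remains open. All four compounds share the 2-hydroxyphenyl group, so whether these gaps persist with another group there is also unknown.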